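Swapping hydroxy for fluoro with the amino group kept

The compounds below may be only part of what the source reports. "The series", "measured", "known", "first", "only" and "open" are said of these compounds alone.

In a functional assay on HL-60 cells (Homo sapiens) for cytotoxicity, read by MTT assay, with a stated time of 72 h (on this read-out lower numbers stand for stronger inhibition and higher numbers for weaker inhibition), compound 3 (`COc1ccc(-c2c(-c3cc(N)c(OC)c(OC)c3)ncn2C)cc1O`) gives 4600 nM and so holds the lowest number measured. In this assay compound 2 (`COc1ccc(-c2c(-c3cc(Br)c(OC)c(OC)c3)ncn2C)cc1F`) gives 9700 nM as a clearly higher number. Compound 1 (`COc1ccc(-c2c(-c3cc(Cl)c(OC)c(OC)c3)ncn2C)cc1F`) gives > 10000 nM as a limit of the assay and not a number.

Compound 4 (`COc1ccc(-c2c(-c3cc(N)c(OC)c(OC)c3)ncn2C)cc1F`) differs from compound 3 by a single swap (fluoro in place of hydroxy on an aromatic carbon) with fluoro in place of hydroxy on an aromatic carbon. Compound 1 and compound 2 carry the same fluoro but lack the amino group. Going by the values given here, the one measured step is an at least 1.0-fold lower number from compound 1 to compound 2 (0.01 log units; that floor lies within the scatter) and it exchanges bromo for chloro at another place, so it says little about this swap. Among the compounds with values here, no measured step compares hydroxy with fluoro, so no step beyond the scatter is expected in this assay and neither direction is favoured. The expected move is a 1.0-fold lower number from compound 3 to compound 4 (0.01 log units; within the scatter) for this swap. For compound 4 the estimated value is 4500 nM with an expected range from 1000 nM to 10000 nM in this wide guess.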

Compound 4, half-maximal inhibitory concentration: > 10000 nM
Compound 4: a limit, no number (the forecaster's own chance of this, stated with the estimate: 20%); at least 2.2-fold (0.34 log units) between middle value and limit.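

With the amino group kept, the hydroxy on this aromatic carbon, ortho to a methoxy group, counts in this assay: fluoro in its place gives an at least 2.1-fold higher number from compound 3 to compound 4 (0.33 log units; beyond the scatter). With fluoro kept, amino in place of bromo gives an at least 1.0-fold higher number from compound 2 to compound 4 (0.01 log units; that floor lies within the scatter), so the amino group shows no gain beyond the scatter in this pair. The full size of these steps stays unknown, and the step between compound 1 and compound 4 cannot be read, because compound 4 sits at a limit of the assay and not at a number: the limit of > 10000 nM in this assay, at which 2 of the 4 values shown sit.

Still open, from the compounds shown here alone, is whether an amine or a carboxylic acid at this same place would hold the number of compound 3 or lose it as fluoro does. Also open, going by these compounds, is whether hydroxy would lower the number with bromo in place of the amino group.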